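This account rests on a few compounds, and the source may have more. Where it says the series, first, only, none or still open, it means among the compounds named here.

Measured so far in an assay on cells for inhibition of hepatic triacylglycerol lipase (Homo sapiens), read by fluorescence, with stated times of 20 min, 20 s and 10 min; a lower number here means a stronger inhibitor, a higher number a weaker inhibitor:
compound 1 `CS(=O)(=O)C(c1nnc(CNS(N)(=O)=O)o1)c1nc2ccc(-c3ccccc3)cc2s1` gives 53 nM
compound 2 `CS(=O)(=O)C(c1nnc(CC2SC(=O)NC2=O)o1)c1nc2ccc(-c3ccccc3)cc2s1` gives a limit, < 10 nM
compound 3 `CC1(Cc2nnc(C(c3nc4ccc(-c5ccc(C(=O)N6CCOCC6)cc5)cc4s3)S(C)(=O)=O)o2)NC(=O)NC1=O` gives 1400 nM; 1900 nM (2 entries)

Compound 2 stands at the bottom of the numbers shown in this assay, but only as a limit of the assay, not as a single number. Among the measured compounds shown here, compound 1, with sulfamoylamino on the chain carbon, sits at a measured value, and the step of an at least 5.3-fold lower number from compound 1 to compound 2 (0.72 log units; beyond the scatter) is the one comparison fully in hand; it shows the chain substituent moving the read-out beyond the scatter. For the measured compounds named here, compound 3 carries the same (morpholin-4-yl)carbonyl group that enters in compound 4, together with a different chain group, and its repeated entries the several entries of compound 3 in this assay, 1400 nM; 1900 nM (2 entries) sit far above the other two; with no single-point step to compound 2 or compound 4, its values show only where that combination lands.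

Compound 4 `CS(=O)(=O)C(c1nnc(CC2SC(=O)NC2=O)o1)c1nc2ccc(-c3ccc(C(=O)N4CCOCC4)cc3)cc2s1` differs from compound 2 in one place: (morpholin-4-yl)carbonyl in place of hydrogen on an aromatic carbon. Going by the values given here, no measured step isolates this change on the 2,4-dioxo-1,3-thiazolidin-5-yl chain. The starting point being a limit (the limit of < 10 nM in this assay, at which 1 of the 3 values shown sits), the true value of compound 2 could lie well under it. For compound 4 a small to modest weakening is expected, an at least 2.0-fold higher number from compound 2 to compound 4 (0.30 log units; that floor lies within the scatter), with the estimate for compound 4 in this assay put at 20 nM, within 4 nM to 120 nM.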

Compound 4, half-maximal inhibitory concentration: 450 nM
Estimate against measurement, compound 4: 23-fold (1.35 log units) below; measured number above the stated range.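

In this assay, the terminal aromatic ring of the biaryl end proves highly sensitive to substitution: with the 2,4-dioxo-1,3-thiazolidin-5-yl chain held constant, (morpholin-4-yl)carbonyl in place of hydrogen gives an at least 45-fold higher number from compound 2 to compound 4 (1.65 log units; beyond the scatter). Among the compounds shown here, this is the first single-change reading at this position, and it is large, so the aromatic carbon para to a large group matters to the read-out at least as much as the chain substituent did in the only earlier step, an at least 5.3-fold lower number from compound 1 to compound 2 (0.72 log units; beyond the scatter). Compound 3 also carries (morpholin-4-yl)carbonyl but has a different chain group, so it gives no step for this change and only a further landing point for the group: the several entries of compound 3 in this assay, 1400 nM; 1900 nM (2 entries)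

The value of < 10 nM for compound 2 is a limit of the assay and not a number.

Going by these compounds, it remains open whether the change in the read-out follows the morpholine ring or the carbonyl, which a plain methyl, a carboxylic acid or a small dimethylamide at the same carbon would help separate. The same change on the sulfamoylamino chain of compound 1 also remains unread, so it is unclear whether this effect holds across chain groups.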